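Furan-2-yl in place of thiophen-2-yl: compound 4

This account rests on a few compounds, and the source may have more. Where it says the series, first, only, none or still open, it means among the compounds named here.

Measured so far in a functional assay on A549 cells (Homo sapiens) for antiproliferative activity; on this read-out higher numbers stand for an effect only at larger amounts of compound and lower numbers for an effect already at smaller amounts:
compound 1, `c1coc(-c2ccnc(-c3cccs3)c2)c1`, 118000 nM
compound 2, `C(=C/c1ccco1)\c1cc(-c2ccco2)cc(-c2cccs2)n1`, 118000 nM
compound 3, `c1ccc(-c2cc(-c3ccco3)ccn2)nc1`, 118000 nM

On these numbers compound 1 stands level with compound 2 and compound 3 at the digits shown; all three values fall within the scatter of one another, so no order among them can be read off. For the measured compounds named here, the one step measured between neighbours, from compound 1 to compound 2 no change at the digits printed from compound 1 to compound 2 (within the scatter), comes with 2-(furan-2-yl)ethenyl in place of hydrogen on an aromatic carbon and is flat. For compound 3 against compound 1 no step is computed; the two values simply coincide at the digits shown.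

Compound 4, `c1coc(-c2ccnc(-c3ccco3)c2)c1`, differs from compound 1 by furan-2-yl in place of thiophen-2-yl on an aromatic carbon. Going by the values given here, no measured step exchanges one five-membered aromatic ring for another, so nothing bears directly on this change; the only change measured, from compound 1 to compound 2, stayed within the scatter, and compound 3 sits at the same value. The expectation is therefore a step of no size beyond the scatter, no change at the digits printed from compound 1 to compound 4 (within the scatter). For compound 4 the estimated value in this assay is 118000 nM, with a range from 50000 nM to 250000 nM.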

Compound 4, half-maximal effective concentration: 118000 nM
Compound 4: the middle estimate sits on the measured number at the digits printed; the range from low to high includes it.
By their numbers in this assay, from the lowest: compounds 1, 2, 3 and 4 (each within the scatter of the next).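

In this assay, furan-2-yl in place of thiophen-2-yl, on an aromatic carbon of a six-membered aromatic ring with 1 nitrogen and next to the ring nitrogen, gives no change at the digits printed from compound 1 to compound 4 (within the scatter). For the compounds shown here, this is the first step to exchange one five-membered aromatic ring with 1 hetero atom for another, with oxygen entering and sulfur leaving at an equal count of heavy atoms; the only earlier step, no change at the digits printed from compound 1 to compound 2 (within the scatter), placed 2-(furan-2-yl)ethenyl on a hydrogen-bearing aromatic carbon and left both rings in place. No evidence at hand speaks to why this exchange leaves the read-out flat.

Open, as far as these compounds go, is whether the read-out at this position responds to anything other than an aromatic ring, such as a primary amine, a carboxylic acid or a longer alkyl chain. Also open, from the compounds shown here alone, is whether any change on the shared core moves the read-out away from the value given by compound 4, 118000 nM, which all four compounds share at the digits printed.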